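Shortening the carbamate-bearing chain on a bicyclic lactone core

A few compounds are considered here, and "the series" means these few. Any claim that something is new, unique, unknown or untested is made for them only; others in the source may bear on it.

Measured compounds:
compound 1 `CC(C)(C)OC(=O)NCCC[C@@H]1N=C2C[C@@H]3C[C@@H](C3(C)C)[C@]2(C)OC1=O`: 6600 nM
compound 2 `C[C@H]1N=C2C[C@H]3C[C@H](C3(C)C)[C@@]2(C)OC1=O`: 42000 nM
compound 3 `CC(C)(C)OC(=O)NCCCC[C@H]1N=C2C[C@H]3C[C@H](C3(C)C)[C@@]2(C)OC1=O`: 15900 nM

Of the compounds shown here, three sharing one bicyclic lactone core have been tested in a functional assay on PC-3 cells (Homo sapiens) for antiproliferative activity, read by sulforhodamine B assay, with a stated time of 48 h; a lower number here means a stronger inhibitor, a higher number a weaker inhibitor. Compound 3 sits second highest of the three numbers in this assay: its nearest neighbour is compound 1, whose number is lower by a margin beyond the scatter, and its furthest is compound 2, whose number is higher, again beyond the scatter. Compound 2, the smallest of the set with only a methyl on the lactone carbon, gives the weakest result of the three.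

Compound 4 `CC(C)(C)OC(=O)NCCC[C@H]1N=C2C[C@H]3C[C@H](C3(C)C)[C@@]2(C)OC1=O` has not yet been measured. It differs from compound 3 in one place: (tert-butoxycarbonyl)amino in place of ((tert-butoxycarbonyl)amino)methyl on a saturated chain carbon, three bonds along the chain from a saturated ring carbon. Compound 1 carries the same shorter chain as compound 4, though on the opposite stereochemical series of the core, and in this assay compound 1 gives 6600 nM.

For the measured compounds named here, no measured pair differs by this chain shortening alone, so the size of the step is an expectation only. Since compound 1 with the shorter chain gives 6600 nM, a modest move toward a lower number is expected, a 2.0-fold lower number from compound 3 to compound 4 (0.30 log units; within the scatter). Compound 4 is therefore estimated at 8000 nM, within a range from 3000 nM to 25000 nM.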

Compound 4, half-maximal inhibitory concentration: 60000 nM
For compound 4 the middle estimate is 7.5-fold (0.88 log units) below the measured one; measured number above the stated range.
By their numbers in this assay, from the lowest: compound 1; then compound 3; then compounds 2 and 4 (each within the scatter of the next).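

In this assay, the change to (tert-butoxycarbonyl)amino in place of ((tert-butoxycarbonyl)amino)methyl on a saturated chain carbon, three bonds along the chain from a saturated ring carbon, now has a measured size and direction within one stereochemical series: there is a 3.8-fold higher number from compound 3 to compound 4 (0.58 log units; beyond the scatter), so the shorter chain goes with the weaker result in this pair. Compound 1 also proves a poor stand-in for its mirror image, with a 9.1-fold higher number from compound 1 to compound 4 (0.96 log units; beyond the scatter), and the shorter chain therefore does not give one result regardless of the configuration of the core. That gap can be put down to configuration alone, because no other structural difference separates the pair: the fact that compounds 1 and 4 differ only in the configuration as drawn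

The compounds shown leave open how chain length acts on the core as drawn in compound 1, and whether the direction seen in this single pair would hold for a longer chain. Also open, on these data alone, is how a free primary amine or a carboxylic acid in place of the tert-butoxycarbonyl-protected amine would read in this assay on either form of the core.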